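Straight butoxy chain replaces branched one in a cinnamoyl triketone

The source may hold more compounds than are shown below. What is called first, only, known or untested is meant among the compounds shown, and "the series" means these compounds.

The series shares a core carrying a cinnamoyl enol and a trialkylated ring, with the alkyl groups and the alkoxy substituent varied. Compound 1, `CCCC1=C(OCC(C)C)C(CCC)(CCC)C(=O)/C(=C(O)\C=C\c2ccccc2)C1=O`, gives 1.7 uM in a functional assay on A549 cells (Homo sapiens) for antiproliferative activity, read by sulforhodamine B assay, with a stated time of 3 days; a lower number here means that less compound is needed, a higher number that more compound is needed for the effect; this is the lowest number of the three measured compounds, and its distance to the others lies beyond the scatter. Compound 2, `COC1=C(CC(C)C)C(=O)/C(=C(O)/C=C/c2ccccc2)C(=O)C1(CC(C)C)CC(C)C`, gives 4.4 uM in this assay, and compound 3, `COC1=C(CCC(C)C)C(=O)/C(=C(O)/C=C/c2ccccc2)C(=O)C1(CCC(C)C)CCC(C)C`, gives 18.4 uM. Compound 4, `CCCCOC1=C(CCC)C(=O)/C(=C(O)/C=C/c2ccccc2)C(=O)C1(CCC)CCC`, has not been measured. It has the same atoms as compound 1, joined differently: propyl in place of isopropyl on a saturated chain carbon bound to an oxygen on an unsaturated carbon. Put another way, isobutoxy becomes butoxy while the three propyl groups on the ring stay in place. Among the compounds with values here, no measured pair in the set shows a change of this kind, so there is no directly comparable step. The estimate is that the change from compound 1 to compound 4 is a 1.2-fold higher number from compound 1 to compound 4 (0.07 log units; within the scatter), that is, no move beyond the scatter. Compound 4 is therefore expected to give about 2 uM, with a likely range from 0.9 uM to 4.5 uM.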

Compound 4, concentration for half-maximal effect: 7.1 uM
Compound 4: middle estimate off by 3.6-fold (0.55 log units), on the low side, and the stated range ends below it.
By their numbers in this assay, from the lowest: compound 1; then compounds 2 and 4 (each within the scatter of the next); then compound 3.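

Replacing isobutoxy with butoxy while the three propyl groups stay in place is not a neutral rearrangement in this assay (a 4.2-fold higher number from compound 1 to compound 4 (0.62 log units; beyond the scatter)). Within the data shown here, this is the first comparison in the set that isolates a single place, and it shows that the branching of the chain on a saturated chain carbon bound to an oxygen on an unsaturated carbon affects this read-out, even though propyl and isopropyl have the same count of heavy atoms. Nothing among the data given explains this step.

One pair cannot show whether this holds with other alkyl groups on the shared core, since compounds 2 and 3 differ from compound 1 in more than one place. Also open, going by these compounds, is how a longer chain, such as hexyloxy, or a chain ending in an amine would behave on this oxygen.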